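The source may hold more compounds than are shown below. What is called first, only, known or untested is meant among the compounds shown, and "the series" means these compounds.

Compound 1 `ClCc1cccc(Cn2cnc3c(Cl)nc(Cl)nc32)c1`: 6310 nM
Compound 2 `ClCc1ccc(Cn2cnc3ncnc(Cl)c32)cc1`: 4260 nM
Compound 3 `ClCc1cccc(Cn2cnc3ncnc(Cl)c32)c1`: 4460 nM

Of the compounds shown here, three have been measured in a functional assay on NCI-H460 cells (Homo sapiens) for cytotoxicity, read by sulforhodamine B assay, with a stated time of 48 h; a lower number here means a stronger inhibitor of growth, a higher number a weaker inhibitor of growth. Compound 2 gives 4260 nM, the lowest of the three numbers, but the others lie close: compound 3 gives 4460 nM, within the scatter of compound 2, and compound 1 gives 6310 nM, also within the scatter. None of the three can therefore be called stronger or weaker than the others in this assay.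

Compound 4 `ClCc1ccc(Cn2cnc3nc(Cl)nc(Cl)c32)cc1` has not yet been measured. It differs from compound 2 by a single change: chloro in place of hydrogen on an aromatic carbon. Among the compounds with values here, the only guide to what such a change does comes from compound 1 and compound 3, which share the same benzyl group; compound 1 carries two chloro groups on the shared core and gives 6310 nM, while compound 3 carries one and gives 4460 nM, two numbers within the scatter of each other.

On that basis no step beyond the scatter is expected from compound 2 to compound 4 in this assay, with the estimated step being a 1.3-fold higher number from compound 2 to compound 4 (0.11 log units; within the scatter). Compound 4 is expected to give about 5500 nM in this assay, most likely between 2500 nM and 12000 nM.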

Compound 4, concentration for total growth inhibition: 35500 nM
Compound 4: middle estimate off by 6.5-fold (0.81 log units), on the low side; measured number outside the range, above it.
By their numbers in this assay, from the lowest: compounds 2, 3 and 1 (each within the scatter of the next); then compound 4.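

Replacing hydrogen with chloro on the aromatic carbon between two ring nitrogen atoms is not a silent change here: this assay shows an 8.3-fold higher number from compound 2 to compound 4 (0.92 log units; beyond the scatter), a step beyond the scatter that marks a weaker inhibitor of growth. This is the first comparison among these compounds in which only one place differs, so it ties a clear loss of growth inhibition to this position and this chloro group, at least with the benzyl group of compound 2. No measurement is available to explain why the chloro group has this effect.

This single pair leaves open whether the loss belongs to chloro specifically or would also appear with another group at the same carbon, such as an amine or a methoxy group. It also leaves open whether the same change would have a similar effect on compound 3, which carries its chloromethyl group at a different place on the benzyl ring.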